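A few compounds are considered here, and "the series" means these few. Any claim that something is new, unique, unknown or untested is made for them only; others in the source may bear on it.

Measured compounds in a functional assay on HeLa cells (Homo sapiens) for inhibition, read by cell counting, with a stated time of 4 days; a lower number here means a stronger inhibitor, a higher number a weaker inhibitor:
- compound 1, `CCOc1ccc(-c2nn3cc(-c4cccc(N)c4)nc3s2)cc1`: 94000 nM
- compound 2, `C=C(Br)C(=O)Nc1cccc(-c2cn3nc(-c4ccc(OCC)cc4)sc3n2)c1`: 1100 nM

Going by the values given here, compound 1 stands at the highest of the two numbers in this assay; its nearest neighbour is compound 2, and the step between them, an 85-fold lower number from compound 1 to compound 2 (1.93 log units; beyond the scatter), is the only measured step. That step changes a different part of the molecule and says nothing direct about the aromatic carbon that is varied next.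

Compound 3, `Cc1ccc(-c2nn3cc(-c4cccc(N)c4)nc3s2)cc1`, differs from compound 1 by methyl in place of ethoxy on an aromatic carbon; the shared core and the aniline nitrogen with its free hydrogen are unchanged. Among the compounds with values here, no measured pair varies this position, so there is no step on which to build a direction. The change is small in atom count and leaves the rest of compound 1 untouched, so the expected outcome is a number close to that of compound 1, with a step, no change at the digits printed from compound 1 to compound 3 (within the scatter), that is expected to stay within the scatter in this assay. Compound 3 is therefore estimated at 94000 nM, with a range from 30000 nM to 300000 nM.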

Compound 3, half-maximal inhibitory concentration: 8900 nM
Compound 3: middle estimate off by 11-fold (1.02 log units), on the high side, outside the stated range (below it).
By their numbers in this assay, from the lowest: compound 2; then compound 3; then compound 1.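

In this assay the aromatic carbon para to a large group proves sensitive: methyl in place of ethoxy is a large change in the number (an 11-fold lower number from compound 1 to compound 3 (1.02 log units; beyond the scatter)), not a neutral exchange. Going by these compounds alone, the only earlier step lay on the nitrogen on an aromatic ring, so this result adds a second place on the molecule where a single change moves the number beyond the scatter, here with the free aniline nitrogen left as it is. In this one pair the lower number goes with the group of fewer heavy atoms, and nothing available bears on the reason for the step.

One pair cannot separate the loss of the oxygen from the shortening of the group, and methoxy, ethyl, a bare hydrogen or a longer chain such as propoxy at this carbon would tell these apart. On these data alone, it also remains open whether the (1-bromoethenyl)carbonyl group on the nitrogen gives a step of similar size when the aromatic carbon carries methyl instead of ethoxy.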